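Series notes: ethoxycarbonyl replaced on compound 1

The source may report more compounds than this note shows. Statements on the series, on what has been measured and on what is new or still open speak of the compounds shown alone.

Measured compounds:
compound 1, `CCOC(=O)SCC(=O)c1ccc(OC)cc1`: 5360 nM
compound 2, `CCSC(=S)SCC(=O)c1ccc(-c2ccc(N)cn2)s1`: 43 nM
compound 3, `CCSC(=S)SCC(=O)c1ccc(S(=O)(=O)Nc2ccc(OC)cc2)cc1`: 245 nM

In an assay on HEK293 cells for inhibition of protein deacetylase HDAC6 (Homo sapiens) (on this read-out higher numbers stand for weaker inhibition and lower numbers for stronger inhibition), compound 1 gives 5360 nM, the highest of the three numbers. For the measured compounds named here, compound 3 gives 245 nM and compound 2 gives 43 nM; both lie well below compound 1, yet each differs from it in more than one place, so no single-change step is available within the measured set. Compound 4, `CCNC(=S)SCC(=O)c1ccc(OC)cc1`, differs from compound 1 only in the change (a group of 5 heavy atoms (3 carbon, 1 nitrogen, 1 sulfur; no ring) in place of a group of 5 heavy atoms (3 carbon, 2 oxygen; no ring), on a sulfur). Going by the values given here, no measured pair isolates this exchange, so the size of the step is uncertain; a move toward a lower number of moderate size is expected, but a result within the scatter cannot be excluded. Compound 4 is expected at 2000 nM in this assay, within 600 nM to 7000 nM. The step this estimate implies is a 2.7-fold lower number from compound 1 to compound 4 (0.43 log units; beyond the scatter), an expectation rather than a measurement.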

Compound 4, half-maximal inhibitory concentration: 94 nM
Beside the measured number, compound 4's estimate is 21-fold (1.33 log units) above it; measured number outside the range, below it.
By their numbers in this assay, from the lowest: compound 2; then compound 4; then compound 3; then compound 1.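

On a sulfur whose other neighbours are: saturated chain carbon, replacing ethoxycarbonyl with the group of 5 heavy atoms (3 carbon, 1 nitrogen, 1 sulfur) gives a 57-fold lower number from compound 1 to compound 4 (1.76 log units; beyond the scatter) in this assay on an otherwise unchanged core. This first single-change reading shows that the position responds strongly even though the heavy-atom count stays the same, with 1 hydrogen-bond donor entering where the leaving group has 0. Nothing available bears on why the step is this large.

Going by these compounds, the exchange alters both atoms together, so their separate contributions remain open. On these data alone, it is also open how a dimethylamino or propylamino group on the same thiocarbonyl would read.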